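A few compounds are considered here, and "the series" means these few. Any claim that something is new, unique, unknown or untested is made for them only; others in the source may bear on it.

Working notes on the series. Compound 1 `COc1ccc(/C=C/c2ccc3ccccc3c2)cc1` and compound 3 `COc1ccc(/C=C/c2ccc3ccccc3c2)cc1F` share a core; compound 3 carries fluoro in place of hydrogen on an aromatic carbon. Compound 2 `COc1cccc(/C=C\c2ccc3ccccc3c2)c1` has the same atoms as compound 1 joined differently, and the difference between the two cores is not broken down here. Compound 4 `COc1cc(/C=C\c2ccc3ccccc3c2)ccc1F` is the still unmeasured member and differs from compound 2 by fluoro in place of hydrogen on an aromatic carbon.

In a functional assay on P388 cells (Mus musculus) for inhibition (on this read-out lower numbers stand for stronger inhibition and higher numbers for weaker inhibition), compound 1 gives > 5000 nM, which is a limit of the assay and not a number. Compound 1 thus sits at the limit of > 5000 nM in this assay, at which 1 of the 3 values shown sits. In this assay compound 3 gives 4490 nM. In this assay compound 2 gives 1920 nM, the lower of the two numbers, with compound 3 the nearest at a gap beyond the scatter.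

The measured step is an at least 1.1-fold lower number from compound 1 to compound 3 (0.04 log units; that floor lies within the scatter). The change from compound 2 to compound 4 is the same kind of change: in both the fluoro enters ortho to a methoxy group, but in compound 3 it stands meta to a large group and in compound 4 para to a large group. The expected step is a 1.3-fold lower number from compound 2 to compound 4 (0.11 log units; within the scatter), resting on the measured step of an at least 1.1-fold lower number from compound 1 to compound 3 (0.04 log units; that floor lies within the scatter) lying within the scatter. Compound 4 is therefore estimated at 1500 nM, with a likely range from 600 nM to 4000 nM.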

Compound 4, half-maximal inhibitory concentration: 450 nM
Beside the measured number, compound 4's estimate is 3.3-fold (0.52 log units) above it; the measured number lies below the stated range.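

In this assay, fluoro in place of hydrogen on an aromatic carbon, ortho to a methoxy group and para to a large group, gives a 4.3-fold lower number from compound 2 to compound 4 (0.63 log units; beyond the scatter), so on the core of compound 2 the change has a readable effect on inhibition. Whether that effect carries over from one core to the other in size cannot be settled, and the two cores can only be set side by side with this reservation: the same change on two cores in this assay, an at least 1.1-fold lower number (0.04 log units; that floor lies within the scatter) from compound 1 to compound 3 and a 4.3-fold lower number (0.63 log units; beyond the scatter) from compound 2 to compound 4; the limit leaves it open whether they differ
The pair from the core of compound 1 therefore supports no claim that the change behaves alike on both cores, nor any claim that it behaves differently, and the comparison rests on a value that is a limit and not a number: the limit of > 5000 nM in this assay, at which 1 of the 4 values shown sits.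

The compounds shown leave open whether the step on the core of compound 2 belongs to fluoro itself or would also appear with chloro, a hydroxy group or an amine in the same place. They also leave open whether the step would persist with an ethoxy group or a hydroxy group in place of the methoxy group, or with fluoro elsewhere on the same ring.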